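This account rests on a few compounds, and the source may have more. Where it says the series, first, only, none or still open, it means among the compounds named here.

Three compounds built on one shared core were run in a functional assay on U-87MG ATCC cells for antiproliferative activity against U-87 MG (Homo sapiens), read by spectrophotometry, with a stated time of 2 days; a lower number here means a stronger inhibitor of growth, a higher number a weaker inhibitor of growth. Compound 1, `COc1ccc(Nc2ncc(C(F)(F)F)c(N3Cc4cccc(N(C)S(C)(=O)=O)c4C3)n2)cc1C(F)(F)F`, gives 29400 nM in this assay. Compound 2, `CN(c1cccc2c1CN(c1nc(Nc3ccc(Cl)c(C(F)(F)F)c3)ncc1C(F)(F)F)C2)S(C)(=O)=O`, reaches only the limit of this assay, > 30000 nM, and no number is read for it. Compound 3, `Cc1ccc(Nc2ncc(C(F)(F)F)c(N3Cc4cccc(N(C)S(C)(=O)=O)c4C3)n2)c(Cl)c1`, likewise stops at the limit of this assay, > 30000 nM. Two of the three values thus sit at the limit of > 30000 nM in this assay, at which 2 of the 3 values shown sit, so compound 3 stands where no number can be read. The step of an at least 1.0-fold higher number from compound 1 to compound 3 (0.00 log units; that floor lies within the scatter) is only a floor that lies within the scatter, and the step that the two limits leave unreadable from compound 2 to compound 3 has limits at both ends and cannot be read.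

Compound 4, `COc1cc(Nc2ncc(C(F)(F)F)c(N3Cc4cccc(N(C)S(C)(=O)=O)c4C3)n2)c(OC)cc1Cl`, is the next to be measured in this assay. Its change from compound 3 is 4-chloro-2,5-dimethoxyphenyl in place of 2-chloro-4-methylphenyl on a nitrogen on an aromatic ring. The only measured steps that bear on it are the two changes of the group on the nitrogen on the aromatic ring described above, and neither reveals a step beyond the scatter, nor even a readable number. Compound 4 is therefore expected to remain at or near the limit, with a number no higher from compound 3 to compound 4 (the limit leaves the size open) estimated as no step beyond the scatter. Compound 4 is estimated at 30000 nM in this assay, in the range 12000 nM to 60000 nM.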

Compound 4, concentration for 50% growth inhibition: 6200 nM
The estimate for compound 4 lay 4.8-fold (0.68 log units) above the measured number; measured number outside the range, below it.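

In this assay, the group on the nitrogen on an aromatic ring now gives a step that can be told from the scatter, with a 4.7-fold lower number from compound 1 to compound 4 (0.68 log units; beyond the scatter). Against the two compounds held at a limit, the same kind of change gives an at least 4.8-fold lower number from compound 3 to compound 4 (0.68 log units; beyond the scatter) and an at least 4.8-fold lower number from compound 2 to compound 4 (0.68 log units; beyond the scatter), and both are floors only, the true size being open at the limit end: the limit of > 30000 nM in this assay, at which 2 of the 4 values shown sit. Within the data shown here, the earlier steps were a floor within the scatter or could not be read, so compound 4 is the first to show that this place responds at all, and no single piece of 4-chloro-2,5-dimethoxyphenyl accounts for it on these data, as compound 1 also carries a methoxy and compound 2 and compound 3 also carry a chloro.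

The entering group differs from each of the others in several features at once, so the compounds shown cannot say whether the chloro, either methoxy or the pattern of all three carries the step. As far as these compounds go, it also remains open whether a nitrile in place of the chloro, or a hydroxyl or an ethoxy in place of one methoxy, would keep it.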